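The compounds below may be only part of what the source reports. "The series", "measured", "known", "first", "only" and "open" are said of these compounds alone.

Measured compounds in the series:

Compound 1 `Cn1ncc(Cl)c1-c1cc(C(=O)N[C@@H]2CN[C@H](CC(O)CO)C[C@H]2c2ccc(F)c(F)c2)oc1Cl` gives 800 nM in a functional assay on HCT-116 cells (Homo sapiens) for antiproliferative activity, read by sulforhodamine B assay, with a stated time of 72 h; on this read-out higher numbers stand for weaker inhibition and lower numbers for stronger inhibition.
Compound 2 `Cn1ncc(Cl)c1-c1cc(C(=O)N[C@@H]2CN[C@H](CC(O)CO)C[C@H]2c2ccc(Cl)c(Cl)c2)oc1Cl` gives 1110 nM in this assay.
Compound 3 `Cn1ncc(Cl)c1-c1cc(C(=O)N[C@@H]2CN[C@H](CC(N)=O)C[C@H]2c2ccc(Cl)c(Cl)c2)oc1Cl` gives 650 nM in this assay.

Compound 3 shows the lowest number of the three, but its separation from compound 1 and from compound 2 is within the scatter, so no ordering among them can be claimed. For the measured compounds named here, the two steps so far, a 1.4-fold higher number from compound 1 to compound 2 (0.14 log units; within the scatter) and a 1.7-fold lower number from compound 2 to compound 3 (0.23 log units; within the scatter), both fall within the scatter: neither the exchange on the aryl ring nor the exchange of the side chain on the saturated ring carbon has shifted the read-out beyond noise.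

Compound 4 `CCC[C@@H]1C[C@@H](c2ccc(Cl)c(Cl)c2)[C@H](NC(=O)c2cc(-c3c(Cl)cnn3C)c(Cl)o2)CN1` is the next member to be measured. The change from compound 3 is ethyl in place of carbamoyl on a saturated chain carbon bound to a saturated ring carbon. Going by the values given here, the only measured step at the same place is a 1.7-fold lower number from compound 2 to compound 3 (0.23 log units; within the scatter), which was within the scatter; it involved a side chain that kept hydrogen-bond donors and acceptors, whereas the ethyl group in compound 4 carries none, so this step bears on compound 4 only loosely. Among the compounds with values here, no measured pair shows what removing all donors and acceptors from this side chain does. The expectation is therefore a step no larger than the scatter in either direction, with wide uncertainty. Compound 4 is expected to give about 800 nM in this assay, the range running from 300 nM to 2500 nM, which corresponds to an expected step of a 1.2-fold higher number from compound 3 to compound 4 (0.09 log units; within the scatter).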

Compound 4, half-maximal inhibitory concentration: 1020 nM
Beside the measured number, compound 4's estimate is 1.3-fold (0.11 log units) below it; the measured number falls inside the stated range.
By their numbers in this assay, from the lowest: compounds 3, 1, 4 and 2 (each within the scatter of the next).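

In this assay, the step of a 1.6-fold higher number from compound 3 to compound 4 (0.20 log units; within the scatter) and the step of a 1.1-fold lower number from compound 2 to compound 4 (0.04 log units; within the scatter) both stay within the scatter, so ethyl, carbamoyl and 1,2-dihydroxyethyl on a saturated chain carbon bound to a saturated ring carbon cannot be told apart with the 3,4-dichlorophenyl group in place. The earlier compounds shown here carried only side chains with hydrogen-bond donors and acceptors at this place; ethyl, with neither, now shows that in this set the read-out does not depend on their presence on the chain beyond the scatter. No supporting data bear on this result, so the absence of a separation remains a bare observation.

From the compounds shown here alone, whether an amine, a carboxylic acid or a longer chain such as hexyl at this place would give a step beyond the scatter stays open. Going by these compounds, all side-chain comparisons here carry the 3,4-dichlorophenyl group, so it also stays open whether ethyl and carbamoyl would behave the same way with the 3,4-difluorophenyl group, which appears only in compound 1.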